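A few compounds are considered here, and "the series" means these few. Any claim that something is new, unique, unknown or untested is made for them only; others in the source may bear on it.

Measured in a physicochemical assay for solubility, in phosphate buffer, measured as kinetic solubility, with a stated time of 24 h, at pH 6.5; a higher number here means a more soluble compound, a lower number a less soluble compound:
Compound 1 `CC(C)Oc1cc(Oc2ccc(S(C)(=O)=O)cc2)cc(-c2cccc(=O)[nH]2)c1`: 11000 nM
Compound 2 `CC(C)Oc1cc(Oc2ccc(S(C)(=O)=O)cc2)cc(-c2nccc(=O)[nH]2)c1`: 25000 nM
Compound 3 `CCS(=O)(=O)c1ccc(Oc2cc(O[C@@H](C)CO)cc(-c3nccc(=O)[nH]3)c2)cc1`: 390000 nM

Compound 2 stands second highest of these three numbers, above compound 1 and below compound 3. Compound 4 `CCc1cnc(-c2cc(Oc3ccc(S(C)(=O)=O)cc3)cc(OC(C)C)c2)[nH]c1=O` comes from it by one change: ethyl in place of hydrogen on an aromatic carbon. Among the compounds with values here, the only measured single-place step is a 2.3-fold higher number from compound 1 to compound 2 (0.36 log units; beyond the scatter). It was modest, but it swapped a whole ring and involved no ethyl, so it bears only loosely. Compound 3 differs from compound 2 in more than one place. The new group adds carbon and no hydrogen-bond donors or acceptors, so, starting from compound 2 at 25000 nM, a modest drop in this assay is expected. The expected step is a 2.5-fold lower number from compound 2 to compound 4 (0.40 log units; beyond the scatter). For compound 4 the estimate is 10000 nM, with an expected range of 3000 nM to 30000 nM.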

Compound 4, solubility: 5700 nM
Compound 4: the middle estimate sits 1.8-fold (0.24 log units) above what was measured; measured number inside the range.
By their numbers in this assay, from the lowest: compounds 4 and 1 (each within the scatter of the next); then compound 2; then compound 3.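

In this assay, ethyl in place of hydrogen on an aromatic carbon of the six-membered aromatic ring with 2 nitrogen gives a 4.4-fold lower number from compound 2 to compound 4 (0.64 log units; beyond the scatter) as the first step shown at this position. The combined change of ring and ethyl gives a 1.9-fold lower number from compound 1 to compound 4 (0.29 log units; within the scatter) and so leaves no readable difference between these two compounds. Nothing available explains the ethyl step.

The compounds shown leave open how methyl, a longer chain such as propyl, or an amine would compare at this carbon.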